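The source may report more compounds than this note shows. Statements on the series, on what has been measured and on what is new or still open speak of the compounds shown alone.

Compound 1, with the structure `Cn1cc(/C=C2/C(=O)Nc3ccccc32)c2cc(Nc3nccc(-c4ccc(Cl)cc4Cl)n3)ccc21`, and compound 2, with the structure `Cn1cc(/C=C2/C(=O)Nc3ccccc32)c2cc(Nc3nccc(-c4cccnc4)n3)ccc21`, share a core and differ only in the group on the aromatic carbon of the pyrimidine-type ring. In a functional assay on LNCaP cells (Homo sapiens) for cytotoxicity, read by MTT assay, with a stated time of 48 h (on this read-out higher numbers stand for weaker inhibition and lower numbers for stronger inhibition), compound 1 reaches only a limit, > 100000 nM, a boundary of the measurement rather than a number (the limit of > 100000 nM in this assay, at which 1 of the 2 values shown sits). In this assay, within the data shown here, compound 2 gives 14200 nM, the only proper number among the two values; the step of an at least 7.0-fold lower number from compound 1 to compound 2 (0.84 log units; beyond the scatter) marks the change to this number. Compound 3, with the structure `Cn1cc(/C=C2/C(=O)Nc3ccccc32)c2cc(Nc3nccc(-c4cccs4)n3)ccc21`, carries the change (thiophen-2-yl in place of pyridin-3-yl on an aromatic carbon). Among the measured compounds shown here, only the one measured step bears on it, and it went the other way, toward the stronger number. Compound 3 is therefore expected to lie somewhat weaker than compound 2, as a 1.8-fold higher number from compound 2 to compound 3 (0.25 log units; within the scatter), with the estimate 25000 nM, between 8000 nM and 100000 nM.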

Compound 3, half-maximal inhibitory concentration: 10400 nM
Beside the measured number, compound 3's estimate is 2.4-fold (0.38 log units) above it; measured number inside the range.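

Exchanging pyridin-3-yl for thiophen-2-yl on this aromatic carbon gives a 1.4-fold lower number from compound 2 to compound 3 (0.14 log units; within the scatter) in this assay, so the five-membered ring with sulfur and the six-membered ring with nitrogen cannot be told apart here. Replacing 2,4-dichlorophenyl with thiophen-2-yl gives an at least 9.6-fold lower number from compound 1 to compound 3 (0.98 log units; beyond the scatter), which shows that the change seen with pyridin-3-yl is not confined to that one ring. The size of this step is only a bound, because compound 1 stands at a limit of the assay: the limit of > 100000 nM in this assay, at which 1 of the 3 values shown sits.

The compounds shown leave open whether unsubstituted phenyl at this position would align with compound 2 and compound 3 or with compound 1, and thus whether the chlorine atoms matter. They also leave open how a morpholine or a simple amine would fare on this carbon.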